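Trifluoromethyl for Fluoro: Expecting No Change Beyond Scatter

A few compounds are considered here, and "the series" means these few. Any claim that something is new, unique, unknown or untested is made for them only; others in the source may bear on it.

Compound 1 `Cc1n[nH]c(C(=O)O)c1Cc1ccc(C(F)(F)F)cc1`: 9%
Compound 2 `Cc1n[nH]c(C(=O)O)c1Cc1ccc(-c2ccc(F)cc2)cc1`: 11%

Of the compounds shown here, two have been measured in an assay on isolated protein for inhibition of 2-Hydroxyacid oxidase 2 (Homo sapiens), tested at 1 uM; on this read-out lower numbers stand for a weaker effect and higher numbers for a stronger effect at the one concentration tested. Compound 1 gives 9%, and compound 2 gives 11%. Within the data shown here, the single step between them, a number 2 percentage points higher from compound 1 to compound 2 (within the scatter), comes with 4-fluorophenyl in place of trifluoromethyl on an aromatic carbon. Compound 2 therefore stands within the scatter of compound 1, and the two numbers cannot be told apart.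

Compound 3 `Cc1n[nH]c(C(=O)O)c1Cc1ccc(-c2ccc(C(F)(F)F)cc2)cc1` has not yet been measured. It differs from compound 2 in one place: trifluoromethyl in place of fluoro on an aromatic carbon. Among the measured compounds shown here, the only measured step that bears on this change is the one at the same end of the molecule, and it was within the scatter. Nothing among the numbers points to a move in either direction. Compound 3 is expected to give about 12%, between 0% and 30%. The step this estimate means, a number 1 percentage points higher from compound 2 to compound 3 (within the scatter), is expected to stay within the scatter.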

Compound 3, a percentage reported as inhibition, at one concentration (the size of the read-out at that concentration, not a potency): 5%
For compound 3 the middle estimate is 7 percentage points above the measured one; the range from low to high includes it.
By their numbers in this assay, from the lowest: compounds 3, 1 and 2 (each within the scatter of the next).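

Trifluoromethyl in place of fluoro, on the aromatic carbon para to a large group, comes with a number 6 percentage points lower from compound 2 to compound 3 (within the scatter) in this assay. The earlier compounds shown here did not test this place at all, and it now shows that going from 1 heavy atom to 4 here, with no ring and no hydrogen-bond donors or acceptors on either group, does not separate the two compounds on this read-out. Nothing measured here speaks to a cause for this result.

The compounds shown leave open whether any group at this place can lift the read-out clear of the scatter, since both groups tried there carry only fluorine or carbon and fluorine. An amine or a longer chain at the same carbon would put that question to the test.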